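Exchanging the amide for a nitrobenzylidene imine at the ring carbon

The source may hold more compounds than are shown below. What is called first, only, known or untested is meant among the compounds shown, and "the series" means these compounds.

Of the compounds shown here, three that share one core have been tested in a functional assay on the whole organism (strain albino) for inhibition, with Rattus norvegicus as the target, read by paw edema, with stated times of 1 h and 3 h, at a dose of 18 mmol/kg by the intraperitoneal route; a higher number here means a stronger effect of the compound at the dose given, a lower number a weaker effect. Compound 1 `N#CC1=C(NCC(=O)O)N(c2ccccc2)C(=O)N2CCCCC(N3CCCC3)C12` gives 78.5%. Compound 2 `N#Cc1c2n(c(=O)n(-c3ccccc3)c1=N)CCCCC2N1CCCC1` gives 83.4% in this assay. Compound 3 `CCOC(=O)C(=O)NC1=C(C#N)C2C(N3CCCC3)CCCCN2C(=O)N1c1ccccc1` gives 81.6%, and it stands between the other two on the numbers, with compound 2 higher by a gap within the scatter and compound 1 lower by a gap within the scatter, so no order among the three can be claimed.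

Among the compounds with values here, the only measured step is a number 3.1 percentage points higher from compound 1 to compound 3 (within the scatter), which concerns the same ring carbon that is altered next. Compound 4 `N#CC1=C(/N=C/c2ccc([N+](=O)[O-])cc2)N(c2ccccc2)C(=O)N2CCCCC(N3CCCC3)C12` differs from compound 3 in this way: a group of 11 heavy atoms (7 carbon, 2 nitrogen, 2 oxygen; one six-membered aromatic ring of carbon only) in place of a group of 8 heavy atoms (4 carbon, 1 nitrogen, 3 oxygen; no ring), on a double-bonded ring carbon. Within the data shown here, no measured step shows what an imine with an aromatic ring does at that place, and the one step on that carbon stayed within the scatter. The expectation for compound 4 is therefore a step of a number 1.6 percentage points lower from compound 3 to compound 4 (within the scatter), that is, nothing beyond the scatter in this assay. Compound 4 is estimated at 80%, within a range from 66% to 90%.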

Compound 4, a percentage reported as inhibition, in the whole organism at one dose (the size of the read-out at that dose, not a potency): 81.3%
Compound 4: the middle estimate sits 1.3 percentage points below what was measured; the measured number falls inside the stated range.
By their numbers in this assay, from the lowest: compounds 1, 4, 3 and 2 (each within the scatter of the next).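

At the double-bonded ring carbon, the group with a six-membered aromatic ring of carbon only, entering for ((ethoxycarbonyl)carbonyl)amino, gives in this assay a number 0.3 percentage points lower from compound 3 to compound 4 (within the scatter), and the same group, entering for the group of compound 1, gives a number 2.8 percentage points higher from compound 1 to compound 4 (within the scatter). The earlier step at this carbon involved only groups without a ring, so these steps add that a nitrobenzylidene imine, whose group counts no hydrogen-bond donor, can stand at this position with no change beyond the scatter. Nothing at hand explains this result.

Going by these compounds, whether a benzylidene imine without the nitro group, or with a methoxy group in its place, would behave in the same way remains open. Each compound is read at one dose, and the values describe the size of the effect at that dose only.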